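The compounds below may be only part of what the source reports. "The series", "measured", "known", "first", "only" and "open" are said of these compounds alone.

Compound 1, `O=C1/C(=C\c2ccc(F)cc2)c2ccccc2N1c1c(Cl)cccc1Cl`: 5 ug/mL
Compound 2, `Cc1ccc2nc(Cl)c(/C=C3\C(=O)N(c4c(Cl)cccc4Cl)c4ccccc43)cc2c1`: 100 ug/mL
Compound 3, `O=C1/C(=C\c2ccc(Cl)cc2)c2ccccc2N1c1c(Cl)cccc1Cl`: 2 ug/mL

Of the compounds shown here, three built on one shared core have been tested in a functional assay on KB cells (Homo sapiens) for cytotoxicity, read by MTT assay, with a stated time of 72 h; a higher number here means that more compound is needed for the effect, a lower number that less compound is needed. Compound 1 stands second highest of the three numbers. Its nearest neighbour differs only by chloro in place of fluoro on an aromatic carbon, and that change gives a 2.5-fold lower number from compound 1 to compound 3 (0.40 log units; beyond the scatter), a modest step but beyond the scatter. Compound 2 lies much further away, with a number far higher than that of compound 1.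

The next compound, compound 4, `CN(C)c1ccc(/C=C2\C(=O)N(c3c(Cl)cccc3Cl)c3ccccc32)cc1`, differs from compound 1 in one place: dimethylamino in place of fluoro on an aromatic carbon. Within the data shown here, the only measured step at this same place is the halogen swap just described, and it moved the number only modestly. Among the measured compounds shown here, no measured step introduces a dimethylamino group anywhere, so there is little direct guidance. The halogen swap suggests that changes at this place do not move the number dramatically, so the expectation for compound 4 is a number near that of compound 1, with a wide range, and the step of a 1.2-fold higher number from compound 1 to compound 4 (0.08 log units; within the scatter) is expected. Compound 4 is therefore estimated at 6 ug/mL, between 2 ug/mL and 25 ug/mL.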

Compound 4, concentration for half-maximal effect: 15 ug/mL
Compound 4: the middle estimate sits 2.5-fold (0.40 log units) below what was measured, within the range that was stated.
By their numbers in this assay, from the lowest: compound 3; then compound 1; then compound 4; then compound 2.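

Among these compounds, this result shows that the number at this place on the aromatic ring can rise as well as fall: in this assay, the 4-fluorophenyl to 4-(dimethylamino)phenyl change gives a 3.0-fold higher number from compound 1 to compound 4 (0.48 log units; beyond the scatter), whereas the only earlier step here, the halogen swap, lowered it. Measured from the chloro compound, the same new group gives a 7.5-fold higher number from compound 3 to compound 4 (0.88 log units; beyond the scatter), so the three groups compared at this place now run from chloro, with the lowest number, through fluoro to dimethylamino, with the highest, and both new steps lie beyond the scatter. Nothing available explains why dimethylamino gives a higher number than either halogen.

With a single non-halogen group at this place, the effect of its nitrogen cannot be separated from that of its two carbons, so a plain amino group or a methoxy group could fall nearer either the halogens or dimethylamino. From the compounds shown here alone, a carboxylic acid or a longer chain at the same carbon, and a dimethylamino group on another carbon of this ring, also remain open.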